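This account rests on a few compounds, and the source may have more. Where it says the series, first, only, none or still open, it means among the compounds named here.

Of the compounds shown here, three have been measured in a functional assay on A549 cells (Homo sapiens) for cytotoxicity, read by sulforhodamine B assay, with a stated time of 48 h; a lower number here means a stronger inhibitor, a higher number a weaker inhibitor. Compound 1 `COc1ccc2c(c1)c(C=O)cn2Cc1cn([C@@H]2O[C@H](COC(C)=O)[C@@H](OC(C)=O)[C@H](OC(C)=O)[C@H]2OC(C)=O)nn1` is built on a different core from the others, and in this assay compound 1 gives 106000 nM. Compound 2 `CC(=O)OC[C@H]1O[C@@H](n2cc(CN3C(=O)/C(=C/c4ccc(C)cc4)c4ccccc43)nn2)[C@H](OC(C)=O)[C@@H](OC(C)=O)[C@@H]1OC(C)=O` carries a 4-methylphenyl group on a double-bonded chain carbon bound to a double-bonded ring carbon, and in this assay compound 2 gives 16000 nM, the lowest of the three numbers, well apart from the number of compound 1. Compound 3 `CC(=O)OC[C@H]1O[C@@H](n2cc(CN3C(=O)/C(=C\c4ccc(C)cc4)c4ccccc43)nn2)[C@H](OC(C)=O)[C@@H](OC(C)=O)[C@@H]1OC(C)=O` has the same atoms and bonds as compound 2, and in this assay compound 3 gives 16500 nM. The step of a 1.0-fold higher number from compound 2 to compound 3 (0.01 log units; within the scatter) lies within the scatter, which is consistent with the fact that compounds 2 and 3 differ only in the configuration as drawn.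

Compound 4 `CC(=O)OC[C@H]1O[C@@H](n2cc(CN3C(=O)/C(=C/c4ccco4)c4ccccc43)nn2)[C@H](OC(C)=O)[C@@H](OC(C)=O)[C@@H]1OC(C)=O` is the next compound in the series. It differs from compound 2 by furan-2-yl in place of 4-methylphenyl on a double-bonded chain carbon bound to a double-bonded ring carbon. Going by the values given here, none of the measured steps concerns an exchange of this aromatic group; the only measured step, that from compound 2 to compound 3, is a change of drawn geometry and says nothing about the aryl ring. The expectation for compound 4 therefore rests on compound 2 alone, and the step of a 1.1-fold higher number from compound 2 to compound 4 (0.05 log units; within the scatter) is estimated as no change beyond the scatter, with a wide range. In this assay compound 4 is expected to give 18000 nM, between 6000 nM and 55000 nM.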

Compound 4, half-maximal inhibitory concentration: 14500 nM
Beside the measured number, compound 4's estimate is 1.2-fold (0.09 log units) above it, and the stated range covers the measured number.
By their numbers in this assay, from the lowest: compounds 4, 2 and 3 (each within the scatter of the next); then compound 1.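

Going by these compounds alone, at this position, on a double-bonded chain carbon bound to a double-bonded ring carbon, the earlier compounds had varied only the drawn geometry, whereas here the aromatic group itself is exchanged. In this assay, furan-2-yl in place of 4-methylphenyl gives a 1.1-fold lower number from compound 2 to compound 4 (0.04 log units; within the scatter), so a six-membered aromatic ring of carbon only and a five-membered aromatic ring with one hetero atom, which also brings a hydrogen-bond acceptor, cannot be told apart in this measurement, although this rests on a single pair of compounds. Nothing at hand bears on why this exchange leaves the number within the scatter.

The compounds shown leave open whether a group of another kind at this place, such as an amine or a carboxylic acid on the aromatic ring or a longer chain in place of it, would move the number beyond the scatter. They also leave open whether the drawn geometry of the double bond would matter with furan-2-yl, since the comparison of the two geometries is available only for the 4-methylphenyl pair.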